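The source may hold more compounds than are shown below. What is called first, only, known or untested is meant among the compounds shown, and "the series" means these compounds.

Series so far, in a functional assay on B16 cells (Mus musculus) for antiproliferative activity, read by MTT assay, with a stated time of 24 h; a higher number here means a weaker inhibitor, a lower number a stronger inhibitor:
- compound 1 `COc1cc(OC)c(-c2coc3cc(OCC=C(C)C)ccc3c2=O)cc1OC`: 1090 nM
- compound 2 `COc1cc(OC)c(-c2coc3cc(OCc4ccc(F)cc4)ccc3c2=O)cc1OC`: 1120 nM
- compound 3 `COc1cc(OC)c(-c2coc3cc(OCc4ccc([N+](=O)[O-])cc4)ccc3c2=O)cc1OC`: > 10000 nM (a limit, not a number)

Compound 3 gives only a limit, > 10000 nM. The series holds one such reading: the limit of > 10000 nM in this assay, at which 1 of the 3 values shown sits. Its steps from the other two both lie beyond the scatter, so compound 3 is the weakest of the three.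

The next structure is compound 4 `COc1cc(OC)c(-c2coc3cc(OCc4ccccc4C(F)(F)F)ccc3c2=O)cc1OC`, which has 2-(trifluoromethyl)phenyl in place of 4-nitrophenyl on a saturated chain carbon bound to an oxygen on an aromatic ring.

Going by the values given here, three measured steps bear on this change. The nearest is an at least 8.9-fold higher number from compound 2 to compound 3 (0.95 log units; beyond the scatter), with nitro in place of fluoro on an aromatic carbon. The step of an at least 9.1-fold higher number from compound 1 to compound 3 (0.96 log units; beyond the scatter) has a similar size, whereas a 1.0-fold higher number from compound 1 to compound 2 (0.01 log units; within the scatter) stays within the scatter. Compound 3 is thus the only one apart from the others, and compound 4 loses its nitro group. Among the compounds with values here, no measured compound carries trifluoromethyl, so the return is expected to be incomplete or uncertain. A move in this assay towards a lower number is expected, of about the size of the step into compound 3.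

The estimated step is an at least 4.0-fold lower number from compound 3 to compound 4 (0.60 log units; beyond the scatter).

For compound 4 the expected value is 2500 nM, with an estimated range of 700 nM to 10000 nM.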

Compound 4, half-maximal inhibitory concentration: 8550 nM
The estimate for compound 4 lay 3.4-fold (0.53 log units) below the measured number; low and high end bracket the measured number.
By their numbers in this assay, from the lowest: compounds 1 and 2 (each within the scatter of the next); then compound 4. At a limit, above all of these: compound 3.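

In this assay, losing the 4-nitrophenyl group does not by itself return the series to its better level, since 2-(trifluoromethyl)phenyl on this saturated chain carbon bound to an oxygen on an aromatic ring gives a 7.6-fold higher number from compound 2 to compound 4 (0.88 log units; beyond the scatter) and a 7.8-fold higher number from compound 1 to compound 4 (0.89 log units; beyond the scatter). This shows that a substituted phenyl carrying no nitro group can also stand clear of the 4-fluorophenyl and 2-methylprop-1-en-1-yl members, although the change from 4-fluorophenyl alters both the group on the ring and where it sits, and the two effects cannot be separated here. The reading of compound 3 is a limit, not a number, so the only available comparison with the new compound is an at least 1.1-fold lower number from compound 3 to compound 4 (0.06 log units; that floor lies within the scatter), which leaves the real gap unsettled: the limit of > 10000 nM in this assay, at which 1 of the 4 values shown sits.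

The compounds shown leave open whether the loss in this assay follows trifluoromethyl itself or its place on the ring, a question that 4-(trifluoromethyl)phenyl and 2-fluorophenyl would address. They also leave open how 4-aminophenyl or 4-methoxyphenyl would read at this position, and whether 4-fluorophenyl is matched by other groups on the ring.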